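The compounds below may be only part of what the source reports. "The series", "measured", "known", "first", "only" and "open" are said of these compounds alone.

Compound 1 `Nc1ncnc2c1ccn2COCCO`: in an ADME assay (Fibroblast) for cytotoxicity, with Homo sapiens as the target (on this read-out lower numbers stand for stronger inhibition and higher numbers for weaker inhibition), compound 1 is reported only as a limit, > 100000 nM.
Compound 2 `CC(=O)OCCOCn1cc(C#N)c2c(N)ncnc21`: in this assay compound 2 is reported only as a limit, > 100000 nM.

Neither number is a measured concentration; each marks the limit of what the measurement could resolve. Compound 2 therefore stands level with compound 1 on the numbers shown, because of the limit of > 100000 nM in this assay, at which 2 of the 2 values shown sit.

Compound 3 `N#Cc1cn(COCCO)c2ncnc(N)c12` has not yet been measured. It differs from compound 2 by hydrogen in place of acetyl on an oxygen on a saturated carbon. Among the measured compounds shown here, no pair of measured compounds shows a step that would size this change, so the expectation rests on both measured compounds sitting at the same limit. The expected step is a step that the limit leaves unreadable from compound 2 to compound 3, which is none beyond the usual scatter. Compound 3 is estimated at 200000 nM, with a range from 60000 nM to 600000 nM, and will most likely again be reported only as a limit.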

Compound 3, half-maximal inhibitory concentration: > 100000 nM
Compound 3: no number, only a limit; the forecaster's own chance of this, stated with the estimate: 85%; the middle value lies beyond the limit too.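

Compound 3 also gives only a limit, so neither its step from compound 2 nor its step from compound 1 can be read: the limit of > 100000 nM in this assay, at which 3 of the 3 values shown sit.

Going by these compounds, whether hydrogen in place of acetyl, or cyano in place of hydrogen, changes the result in this assay at all stays open.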